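The compounds below may be only part of what the source reports. "The series", "measured", "known", "first", "only" and "open" are said of these compounds alone.

In an ADME assay on J774 cells (Mus musculus) for cytotoxicity (a higher number here means that more compound is needed for the effect, a lower number that less compound is needed), compound 1, with the structure `Cc1[nH]c2ccccc2c(=O)c1Br`, gives only a limit of > 42000 nM, so no number is known for it; this is the limit at which (the limit of > 42000 nM in this assay, at which 1 of the 3 values shown sits). Compound 2, with the structure `Cc1[nH]c2ccc(Cl)cc2c(=O)c1Br`, gives 21700 nM in this assay. Between them stands one change, (chloro in place of hydrogen on an aromatic carbon), and the step it made is an at least 1.9-fold lower number from compound 1 to compound 2 (0.28 log units; that floor lies within the scatter), though it rests on a limit on one side. Among the measured compounds shown here, compound 3, with the structure `CCCCC#Cc1c(C)[nH]c2ccccc2c1=O`, gives 8900 nM in this assay, the lowest of the two numbers measured so far. It differs from compound 1 in its core by hex-1-yn-1-yl in place of bromo on an aromatic carbon, and the step is an at least 4.7-fold lower number from compound 1 to compound 3 (0.67 log units; beyond the scatter), again measured against a limit. Compound 4, with the structure `CCCCC#Cc1c(C)[nH]c2ccc(Cl)cc2c1=O`, has not yet been measured in this assay. It carries the same change relative to compound 3 that compound 2 carries relative to compound 1: chloro in place of hydrogen on an aromatic carbon. Since this change in compound 2 made a step of an at least 1.9-fold lower number from compound 1 to compound 2 (0.28 log units; that floor lies within the scatter), a step of comparable size is expected here, so from compound 3 the expected step is a 2.0-fold lower number from compound 3 to compound 4 (0.30 log units; within the scatter). The basis is thin, as it rests on a single earlier step that is bounded by a limit, and the expectation is held loosely. Compound 4 is accordingly estimated to give about 4500 nM in this assay, with a likely spread from 2000 nM to 10000 nM.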

Compound 4, half-maximal effective concentration: > 36300 nM
Compound 4 gave a limit, no number; the forecaster's own chance of this, stated with the estimate: 5%; middle value at least 8.0-fold (0.90 log units) away from the limit.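

In this assay compound 4 gives > 36300 nM, which is a limit of the assay and not a number. Chloro in place of hydrogen on an aromatic carbon does not carry over from one core to the other in this small set: on the core of compound 3 the step is an at least 4.0-fold higher number from compound 3 to compound 4 (0.61 log units; beyond the scatter), which runs the opposite way to the step on the core of compound 1, and the two differ by more than the scatter: the same change on two cores in this assay, an at least 1.9-fold lower number (0.28 log units; that floor lies within the scatter) from compound 1 to compound 2 and an at least 4.0-fold higher number (0.61 log units; beyond the scatter) from compound 3 to compound 4, at least 7.8-fold (0.89 log units) apart, beyond the scatter of two such steps. Hex-1-yn-1-yl in place of bromo likewise reverses direction between the two cores, with an at least 1.6-fold higher number from compound 2 to compound 4 (0.22 log units; that floor lies within the scatter), but every one of these steps rests on a limit on one side, so their true sizes stay unknown and the data do not show why the change fails to carry over: the same change on two cores in this assay, an at least 4.7-fold lower number (0.67 log units; beyond the scatter) from compound 1 to compound 3 and an at least 1.6-fold higher number (0.22 log units; that floor lies within the scatter) from compound 2 to compound 4, at least 7.8-fold (0.89 log units) apart, beyond the scatter of two such steps.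

The compounds shown leave open whether chloro would behave the same way beside a shorter or longer alkyne chain, and what fluoro would do in the same place. They also leave open what an amine or a carboxylic acid on this core would do in this assay's read-out, and whether a reversal like this one would appear on a third core.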